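The compounds below may be only part of what the source reports. "The series", "measured", "known", "first", "only" and "open" are said of these compounds alone.

Of the compounds shown here, three share one core and have been tested in a functional assay on the whole organism (strain NMRI) with Mus musculus as the target, with a stated time of 60 min, at a dose of 10 mg/kg by the intraperitoneal route; a higher number here means a stronger effect of the compound at the dose given, a lower number a weaker effect. Compound 1 `CCSc1nnc(Cc2ccc(Cl)cc2Oc2ccccc2F)[nH]1` gives 144% there. Compound 2 `Fc1ccccc1Oc1cc(Cl)ccc1Cc1nnc(SCc2ccccc2)[nH]1` gives 169%, and compound 3 `Nc1nnc(Cc2ccc(Cl)cc2Oc2ccccc2F)o1` gives 129%. Compound 3 therefore stands lowest of the three: compound 1 lies nearest, and compound 2 furthest, as the step of a number 15 percentage points lower from compound 1 to compound 3 (beyond the scatter) and the step of a number 25 percentage points higher from compound 1 to compound 2 (beyond the scatter) show.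

Compound 4 `CCOc1nnc(Cc2ccc(Cl)cc2Oc2ccccc2F)[nH]1` has not yet been measured in this assay. Compared with compound 3 the change is a group of 8 heavy atoms (4 carbon, 3 nitrogen, 1 oxygen; one five-membered aromatic ring with 3 hetero atoms) in place of a group of 6 heavy atoms (2 carbon, 3 nitrogen, 1 oxygen; one five-membered aromatic ring with 3 hetero atoms), on a saturated chain carbon bound to an aromatic carbon. Going by the values given here, the step that bears on this is the one from compound 1 to compound 3, because a number 15 percentage points lower from compound 1 to compound 3 (beyond the scatter) describes the reverse direction of a closely related exchange on the same saturated chain carbon bound to an aromatic carbon. Undoing that modest loss suggests an estimated rise of about a number 13 percentage points higher from compound 3 to compound 4 (beyond the scatter) in this assay for compound 4. Compound 4 is thus expected to give roughly 142% in this assay, most likely between 120% and 165%.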

Compound 4, a percentage reported as activity, at one dose (the size of the read-out at that dose, not a potency): 116%
Compound 4: the middle estimate sits 26 percentage points above what was measured; the measured number lies below the stated range.
By their numbers in this assay, from the lowest: compound 4; then compound 3; then compound 1; then compound 2.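

In this assay, ethoxy in place of ethylsulfanyl on an aromatic carbon gives a number 28 percentage points lower from compound 1 to compound 4 (beyond the scatter), so at this position the atom joining the ethyl chain to the core changes the result. Ethoxy in place of benzylsulfanyl gives a larger change, a number 53 percentage points lower from compound 2 to compound 4 (beyond the scatter), though here the chain differs as well as the joining atom. The exchange at the saturated chain carbon gives a number 13 percentage points lower from compound 3 to compound 4 (beyond the scatter), while the group in compound 1 has the same heavy-atom count as the group in compound 4 yet stands above compound 3, so that count alone does not set the number.

No measurement shown explains these differences. From the compounds shown here alone, it remains open where a benzyloxy group, or an ethylamino group with nitrogen as the joining atom, would fall relative to compound 1 and compound 4.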